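Trifluoromethyl in place of ethyl: compound 3 to compound 4

The source may hold more compounds than are shown below. What is called first, only, known or untested is meant among the compounds shown, and "the series" means these compounds.

In a functional assay on K562 cells (Homo sapiens) for inhibition, read by CCK-8 assay, with a stated time of 72 h (a lower number here means a stronger inhibitor, a higher number a weaker inhibitor), compound 3 (`CCc1ccc(NS(=O)(=O)c2cccc(CCCCCCNC(=O)/C=C/c3cccnc3)c2)cc1`) gives 3.89 nM, the second highest of three numbers. Compound 1 (`O=C(/C=C/c1cccnc1)NCCCCc1ccc(S(=O)(=O)Nc2ccccc2)cc1`) reads higher at 9.56 nM, and compound 2 (`Cc1ccc(C)c(NS(=O)(=O)c2cccc(CCCCCCNC(=O)/C=C/c3cccnc3)c2)c1`) reads lower at 0.84 nM. Compound 4 (`O=C(/C=C/c1cccnc1)NCCCCCCc1cccc(S(=O)(=O)Nc2ccc(C(F)(F)F)cc2)c1`) carries trifluoromethyl in place of ethyl on an aromatic carbon, para to a large group: trifluoromethyl in place of ethyl on an aromatic carbon. Among the measured compounds shown here, the one measured step bearing on this group, 4-ethylphenyl in place of 2,5-dimethylphenyl on a sulfonamide nitrogen, is a 4.6-fold higher number from compound 2 to compound 3 (0.67 log units; beyond the scatter). For the measured compounds named here, it is modest, and no measured compound carries trifluoromethyl, so no direction can be read from the data. The expected result is no change beyond the scatter: a 1.2-fold higher number from compound 3 to compound 4 (0.06 log units; within the scatter). For compound 4 the estimated value is 4.5 nM, with an expected range of 1.3 nM to 14 nM.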

Compound 4, half-maximal inhibitory concentration: 44.9 nM
Estimate against measurement, compound 4: 10-fold (1.00 log units) below, and the stated range ends below it.
By their numbers in this assay, from the lowest: compound 2; then compound 3; then compound 1; then compound 4.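

The group para to a large group on the sulfonamide nitrogen's phenyl ring is not a tolerant position in this assay: trifluoromethyl in place of ethyl gives a 12-fold higher number from compound 3 to compound 4 (1.06 log units; beyond the scatter). Set against the 2,5-dimethylphenyl group, 4-(trifluoromethyl)phenyl gives a 53-fold higher number from compound 2 to compound 4 (1.73 log units; beyond the scatter). Nothing on hand gives a reason for this loss.

Only ethyl and trifluoromethyl can be compared at this position, so the loss cannot yet be placed on a wider trend. From the compounds shown here alone, how a methoxy group, a chlorine atom or a nitrile would read there remains open.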